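A few compounds are considered here, and "the series" means these few. Any claim that something is new, unique, unknown or untested is made for them only; others in the source may bear on it.

Working notes on the series. Compound 1 `COc1cc2c(cc1OC)C(=O)C(CC1CCN(C(=S)Nc3ccccc3[N+](=O)[O-])CC1)C2` and compound 2 `COc1cc2c(cc1OC)C(=O)C(CC1CCN(C(=S)Nc3ccc([N+](=O)[O-])cc3)CC1)C2` share one core and differ only in the aryl group carried on the thiourea nitrogen. In a functional assay on the whole organism (strain Swiss albino) with Mus musculus as the target, in the maximal electroshock model, with a stated time of 4 h (on this read-out higher numbers stand for an effect only at larger amounts of compound and lower numbers for an effect already at smaller amounts), compound 1 gives 300 mg/kg and compound 2 gives 300 mg/kg, so compound 2 stands level with compound 1 at the digits shown; the step of no change at the digits printed from compound 1 to compound 2 (within the scatter) lies within the scatter.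

Compound 3 `CCCCNC(=S)N1CCC(CC2Cc3cc(OC)c(OC)cc3C2=O)CC1` is not yet measured. Relative to compound 2 the change is butyl in place of 4-nitrophenyl on an amide-type nitrogen. Within the data shown here, no measured step bears directly on replacing an aromatic group by a chain on this nitrogen; the one available step, from a 2-nitrophenyl to a 4-nitrophenyl group, left the read-out unchanged, which says little about a butyl group. The expectation is therefore a step of no change at the digits printed from compound 2 to compound 3 (within the scatter) that stays near the scatter, with wide uncertainty. Compound 3 is estimated at 300 mg/kg, in the range 100 mg/kg to 600 mg/kg.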

Compound 3, minimum effective dose: 100 mg/kg
The estimate for compound 3 lay 3.0-fold (0.48 log units) above the measured number; measured number inside the range.
By their numbers in this assay, from the lowest: compound 3; then compounds 1 and 2 (each within the scatter of the next).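

Butyl in place of 4-nitrophenyl on the amide-type nitrogen gives a 3.0-fold lower number from compound 2 to compound 3 (0.48 log units; beyond the scatter) in this assay, and butyl in place of 2-nitrophenyl gives a 3.0-fold lower number from compound 1 to compound 3 (0.48 log units; beyond the scatter). This position therefore responds to the kind of group it carries, although moving the nitro group within the nitrophenyl group gave only no change at the digits printed from compound 1 to compound 2 (within the scatter), and neither nitrophenyl group is needed for an effect in this model. Nothing on hand accounts for the shift.

A single chain leaves open whether the lower number belongs to butyl itself or simply to the loss of the nitrophenyl group. A propyl or hexyl chain, a cyclohexyl group or an unsubstituted phenyl group on this nitrogen would separate chain length, ring and nitro group.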